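From 2,5-dihydroxyphenyl to 2,6-dihydroxyphenyl on the shared core

The source may report more compounds than this note shows. Statements on the series, on what has been measured and on what is new or still open speak of the compounds shown alone.

In a toxicity assay on cells (Fibroblast, Homo sapiens) for cytotoxicity (on this read-out lower numbers stand for stronger inhibition and higher numbers for weaker inhibition), compound 1 `CC(/C=C/C1=CCCCC1(C)C)=C\C=C\C(C)=C\COC(=O)c1cc(O)ccc1O` gives 14000 nM. Compound 2 `CC(/C=C/C1=CCCCC1(C)C)=C\C=C\C(C)=C\COC(=O)c1ccccc1O` gives 150000 nM, which leaves compound 1 with the lower of the two exact numbers. Compound 3 `COc1cc(NC(C)=O)cc(C(=O)OC/C=C(C)/C=C/C=C(C)/C=C/C2=CCCCC2(C)C)c1O` is reported only as a limit, < 10000 nM.

The unmeasured compound 4 `CC(/C=C/C1=CCCCC1(C)C)=C\C=C\C(C)=C\COC(=O)c1c(O)cccc1O` has the same atoms as compound 1, joined differently: 2,6-dihydroxyphenyl in place of 2,5-dihydroxyphenyl on a carbonyl carbon. On the carbonyl carbon, 2,6-dihydroxyphenyl stands in place of 2,5-dihydroxyphenyl.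

Among the measured compounds shown here, one measured step bears on this change: an 11-fold higher number from compound 1 to compound 2 (1.03 log units; beyond the scatter). This large step puts hydrogen in place of hydroxy on an aromatic carbon. Compound 4 loses no hydroxy group, so the change differs in kind, and a step of that full size is not expected. For the measured compounds named here, no measured pair shows directly what this rearrangement does, which leaves the expectation uncertain. Going by the values given here, compound 1 holds the lower exact number, and the one measured change to its ring gave a higher number, so a modest move in that direction seems the most reasonable guess. The expected change is a 2.1-fold higher number from compound 1 to compound 4 (0.33 log units; beyond the scatter), smaller than the measured step. For compound 4 the estimated value is 30000 nM, with an expected range from 8000 nM to 110000 nM.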

Compound 4, half-maximal inhibitory concentration: 14000 nM
For compound 4 the middle estimate is 2.1-fold (0.33 log units) above the measured one, within the range that was stated.
By their numbers in this assay, from the lowest: compounds 1 and 4 (each within the scatter of the next); then compound 2. At a limit, below all of these: compound 3.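

Exchanging 2,5-dihydroxyphenyl for 2,6-dihydroxyphenyl on a carbonyl carbon gives, in this assay, no change at the digits printed from compound 1 to compound 4 (within the scatter), so this read-out does not separate the two arrangements of the ring on the shared core. The second hydroxy group still matters in its new arrangement: an 11-fold lower number from compound 2 to compound 4 (1.03 log units; beyond the scatter) in this assay, a step as large as an 11-fold higher number from compound 1 to compound 2 (1.03 log units; beyond the scatter) in the opposite direction, so both dihydroxyphenyl compounds stand apart from the compound with a single hydroxy group. Nothing shown gives a reason why the two arrangements read alike.

Compound 3 is known only as a limit, < 10000 nM, and its steps to the other compounds cannot be read. As far as these compounds go, it remains open whether an amine or a carboxylic acid in place of one hydroxy group on this ring would stay level with compound 1 and compound 4 or move toward compound 2, and whether a longer chain between the carbonyl carbon and the ring would alter the picture.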